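Swapping the Halogenated Ring on the Amide Nitrogen

The compounds below may be only part of what the source reports. "The series", "measured", "known", "first", "only" and "open" are said of these compounds alone.

Of the compounds shown here, three sharing one core have been tested in a functional assay on THP-1 cells (Homo sapiens) for cytotoxicity, read by MTT assay, with a stated time of 24 h; a lower number here means a stronger inhibitor, a higher number a weaker inhibitor. Compound 1 `Cc1ccc(-n2cc(Cn3nc(N)c4c(C(F)(F)F)cc(-c5ccccc5)nc43)nn2)cc1` gives 98.6 ug/mL. Compound 2 `Nc1nn(Cc2cn(CC(=O)Nc3ccccc3)nn2)c2nc(-c3ccccc3)cc(C(F)(F)F)c12` gives 54.6 ug/mL, and compound 3 `Nc1nn(Cc2cn(CC(=O)Nc3cccc(Cl)c3)nn2)c2nc(-c3ccccc3)cc(C(F)(F)F)c12` gives 37 ug/mL. Compound 3 shows the lowest of the three numbers: the change from compound 1 is a 2.7-fold lower number from compound 1 to compound 3 (0.43 log units; beyond the scatter), while the step of a 1.5-fold lower number from compound 2 to compound 3 (0.17 log units; within the scatter) stays within the scatter, so compound 2 and compound 3 cannot be told apart on these numbers.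

Compound 4 `Nc1nn(Cc2cn(CC(=O)Nc3c(F)cccc3F)nn2)c2nc(-c3ccccc3)cc(C(F)(F)F)c12` has not yet been measured. It differs from compound 3 in one place: 2,6-difluorophenyl in place of 3-chlorophenyl on an amide-type nitrogen. Among the compounds with values here, the only measured step that touches this part of the molecule is a 1.5-fold lower number from compound 2 to compound 3 (0.17 log units; within the scatter), which adds a single chloro to the ring on the amide-type nitrogen and does not move the number beyond the scatter. Compound 4 also keeps the whole arm attached through that nitrogen, which in a 1.8-fold lower number from compound 1 to compound 2 (0.26 log units; within the scatter) gave a change within the scatter. Since the one measured substitution on this ring left the number essentially unchanged, the expected step of a 1.2-fold higher number from compound 3 to compound 4 (0.09 log units; within the scatter) is small and could run either way. Compound 4 is therefore estimated at 45 ug/mL in this assay, with a range from 22 ug/mL to 90 ug/mL.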

Compound 4, half-maximal inhibitory concentration: 43.3 ug/mL
For compound 4 the middle estimate is 1.0-fold (0.02 log units) above the measured one; the measured number falls inside the stated range.
By their numbers in this assay, from the lowest: compounds 3, 4, 2 and 1 (each within the scatter of the next, the first and the last beyond it).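

In this assay, the ring on the amide-type nitrogen has now been changed in a second way. Putting 2,6-difluorophenyl in place of 3-chlorophenyl gives a 1.2-fold higher number from compound 3 to compound 4 (0.07 log units; within the scatter), and putting it in place of plain phenyl gives a 1.3-fold lower number from compound 2 to compound 4 (0.10 log units; within the scatter), so phenyl, 3-chlorophenyl and 2,6-difluorophenyl cannot be told apart at this position, whether the ring carries no halogen, one chlorine or two fluorines. The larger change, with the whole ((2,6-difluorophenyl)carbamoyl)methyl arm replacing 4-methylphenyl on the aromatic nitrogen, gives a 2.3-fold lower number from compound 1 to compound 4 (0.36 log units; beyond the scatter), so compound 4 joins compound 3 in lying beyond the scatter from compound 1, while compound 2 goes against this pattern with a 1.8-fold lower number from compound 1 to compound 2 (0.26 log units; within the scatter); nothing available accounts for these results.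

The rings shown carry only hydrogen, chloro or fluoro, so it remains open whether a ring bearing an amine or a carboxylic acid, or a cyclohexyl group on the amide-type nitrogen, would stay within the scatter of these compounds. As far as these compounds go, it is also open whether a longer chain in place of the methyl link in the arm would move the number beyond the scatter.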